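Settling one stereocentre in the side chain of compound 2

The source may report more compounds than this note shows. Statements on the series, on what has been measured and on what is new or still open speak of the compounds shown alone.

Compound 1 `CCCCCCCCCCCCCCCCO[C@H]1O[C@H](COCC(CO)(CO)CO)[C@@H](O)[C@H](O)[C@H]1NC(=O)CCCC`: 17 uM
Compound 2 `CCCCCCCCCCCCCCCCO[C@H]1O[C@H](COCC(O)CO)[C@@H](O)[C@H](O)[C@H]1NC(=O)CCCC`: 3 uM

Only these two compounds have been measured in a functional assay on A-375 cells (Homo sapiens), read by thymidine incorporation (a higher number here means a weaker inhibitor, a lower number a stronger inhibitor), and compound 2 has the lower number, which makes it the stronger inhibitor of the pair. Going by the values given here, the one measured step is a 5.7-fold lower number from compound 1 to compound 2 (0.75 log units; beyond the scatter). It is a step beyond the scatter, and it puts 1,2-dihydroxyethyl in place of 2-hydroxy-1,1-bis(hydroxymethyl)ethyl.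

The next compound is compound 3 `CCCCCCCCCCCCCCCCO[C@H]1O[C@H](COC[C@@H](O)CO)[C@@H](O)[C@H](O)[C@H]1NC(=O)CCCC`. Its difference from compound 2 is the two compounds have the same atoms and bonds; at least one stereo element is drawn with a configuration in one of them and without one in the other: 1 of 6 stereo elements differ; a stereocentre at a saturated chain carbon is drawn without a configuration in compound 2 and S in compound 3. The measured step exchanged one group for another, whereas here the atoms and bonds stay the same. That step therefore bears on this change only loosely: it shows that the number in this assay responds to a change in this side chain, but not how it responds to configuration. Among the compounds with values here, no measured pair differs in configuration alone, so the expectation is for no step beyond the scatter.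

The estimated change is no change at the digits printed from compound 2 to compound 3 (within the scatter). For compound 3 the expected value is 3 uM, with an estimated range from 1.5 uM to 6 uM.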

Compound 3, concentration for 50% inhibition: 3.4 uM
The estimate for compound 3 lay 1.1-fold (0.05 log units) below the measured number, within the range that was stated.
By their numbers in this assay, from the lowest: compounds 2 and 3 (each within the scatter of the next); then compound 1.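

In this assay, the side chain drawn with an S stereocentre cannot be told apart from the same side chain drawn without a configuration: a 1.1-fold higher number from compound 2 to compound 3 (0.05 log units; within the scatter). The earlier advantage over compound 1 also holds for the compound with the defined stereocentre, at a 5.0-fold lower number from compound 1 to compound 3 (0.70 log units; beyond the scatter), so the preference for 1,2-dihydroxyethyl over 2-hydroxy-1,1-bis(hydroxymethyl)ethyl now rests on two compounds rather than one. What this says about configuration itself is limited, because the comparison is not between two defined forms, and it rests on this fact: the fact that one of compounds 2 and 3 is drawn with a defined configuration and the other without, at the place where they differ.

What the R configuration at this same carbon would give in this assay remains open, so the compounds shown cannot say whether this stereocentre matters to the number at all. Also open, on these data alone, is how the number would respond if an amine or a carboxylic acid stood in place of a hydroxyl group on this side chain.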